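The source may report more compounds than this note shows. Statements on the series, on what has been measured and on what is new or still open speak of the compounds shown alone.

Measured so far in a physicochemical assay for lipophilicity; a higher number here means a more lipophilic compound, a lower number a more polar compound:
Compound 1 `CC(=O)NCc1cccc(Cn2nc(NS(=O)(=O)c3ccc(Cl)s3)c3ccccc32)c1` gives 3.3.
Compound 2 `CC(=O)NCc1cccc(Cn2nc(NS(=O)(=O)c3ccc(Cl)s3)c3c(C(C)=O)cccc32)c1` gives 4.8.

For the measured compounds named here, compound 1 holds the lower of the two numbers; the only measured step from it is a number 1.50 log units higher from compound 1 to compound 2 (beyond the scatter). Compound 3 `CC(=O)NCc1cccc(Cn2nc(NS(=O)(=O)c3ccc(Cl)s3)c3c(C(F)F)cccc32)c1` differs from compound 1 by difluoromethyl in place of hydrogen on an aromatic carbon, on the same aromatic carbon ortho to a fused ring. Going by the values given here, that single acetyl step is the one comparison that bears on this change, and it was large and upward in this assay, so a new group at this carbon is expected to raise the number again, though less. Compound 3 is expected to give 4.1, within 3.6 to 4.6. The expected change is a number 0.80 log units higher from compound 1 to compound 3 (beyond the scatter).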

Compound 3, distribution coefficient: 3.7
For compound 3 the middle estimate is 0.40 log units above the measured one; low and high end bracket the measured number.
By their numbers in this assay, from the lowest: compound 1; then compound 3; then compound 2.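

In this assay, the aromatic carbon ortho to a fused ring does not respond equally to every new group: difluoromethyl in place of hydrogen gives a number 0.40 log units higher from compound 1 to compound 3 (beyond the scatter) and difluoromethyl in place of acetyl gives a number 1.10 log units lower from compound 2 to compound 3 (beyond the scatter). The upward step at this carbon therefore depends on which group enters, and not only on the hydrogen being replaced. Nothing available explains the difference between these two groups.

On these data alone, whether an amine or a carboxylic acid at this carbon would give a number below that of compound 1 remains open. So does whether a longer chain there would exceed compound 2.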